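Methoxy for Bromo on the Sulfonyl Aryl Ring

The source may hold more compounds than are shown below. What is called first, only, known or untested is meant among the compounds shown, and "the series" means these compounds.

Compound 1 `COc1cc(N)c(Cl)cc1C(=O)CCC1CCN(CCNS(=O)(=O)c2cc(Br)ccc2Br)CC1` gives 52%.
Compound 2 `COc1ccc(S(=O)(=O)N2CCC(CCC(=O)c3cc(Cl)c(N)cc3OC)CC2)cc1` gives "not active" (no number reported).
Compound 3 `COc1ccc(S(=O)(=O)NCCN2CCC(CCC(=O)c3cc(Cl)c(N)cc3OC)CC2)cc1Br` gives 72%.

In an assay on HEK293 cells for displacement of a labelled ligand from 5-hydroxytryptamine receptor 6 (Homo sapiens), with a stated time of 60 min, tested at 1 uM, in the presence of a further agent that is not named here (a higher number here means a stronger effect of the compound at the concentration tested, a lower number a weaker effect), compound 3 holds the higher of the two numbers reported; compound 1 stands lower, the gap being a number 20 percentage points higher from compound 1 to compound 3 (beyond the scatter), and compound 2 was reported without a number. Compound 4 `COc1ccc(S(=O)(=O)NCCN2CCC(CCC(=O)c3cc(Cl)c(N)cc3OC)CC2)cc1OC` differs from compound 3 by methoxy in place of bromo on an aromatic carbon. Within the data shown here, the one measured step also alters the group on the sulfonyl sulfur, but it exchanges 2,5-dibromophenyl for 3-bromo-4-methoxyphenyl and says little about a methoxy taking the place of a bromo. Compound 2 carries a methoxy on that ring, yet it differs from compound 3 in more than one place, so its outcome cannot be tied to this swap. With no direct guide, compound 4 is expected to lose some inhibition, by a number 17 percentage points lower from compound 3 to compound 4 (beyond the scatter), giving an estimate of 55% within 30% to 80%.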

Compound 4, a percentage reported as inhibition, at one concentration (the size of the read-out at that concentration, not a potency): 58%
For compound 4 the middle estimate is 3 percentage points below the measured one; the measured number falls inside the stated range.
By their numbers in this assay, from the lowest: compounds 1 and 4 (each within the scatter of the next); then compound 3.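

Methoxy in place of bromo, at the position ortho to a methoxy group, lowers the read-out in this assay (a number 14 percentage points lower from compound 3 to compound 4 (beyond the scatter)), so the bromo on this ring counts for something here. Yet 3,4-dimethoxyphenyl and 2,5-dibromophenyl on the sulfonyl sulfur are not separated (a number 6 percentage points higher from compound 1 to compound 4 (within the scatter)). Nothing measured here explains the drop.

The compounds shown leave open whether chloro, an amine or a hydroxyl at this position would match the bromo. They also leave open how a longer chain to the sulfonamide nitrogen would read.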